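A side-chain swap on compound 1

A few compounds are considered here, and "the series" means these few. Any claim that something is new, unique, unknown or untested is made for them only; others in the source may bear on it.

Compound 1 `Cn1ncc(Cl)c1-c1cc(C(=O)N[C@@H]2CN[C@H](CC(O)CO)C[C@H]2c2ccc(F)c(F)c2)oc1Cl`: 800 nM
Compound 2 `Cn1ncc(Cl)c1-c1cc(C(=O)N[C@@H]2CN[C@H](CC(O)CO)C[C@H]2c2ccc(Cl)c(Cl)c2)oc1Cl`: 1110 nM

Both numbers come from a functional assay on HCT-116 cells (Homo sapiens) for antiproliferative activity, read by sulforhodamine B assay, with a stated time of 72 h; a lower number here means a stronger inhibitor, a higher number a weaker inhibitor. Going by the values given here, the one measured step between them is a 1.4-fold higher number from compound 1 to compound 2 (0.14 log units; within the scatter). Among the compounds with values here, compound 1 therefore cannot be told apart from the only other measured compound.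

Compound 3 `CC(=O)NCC[C@@H]1C[C@@H](c2ccc(F)c(F)c2)[C@H](NC(=O)c2cc(-c3c(Cl)cnn3C)c(Cl)o2)CN1` differs from compound 1 in its side chain: acetamidomethyl in place of 1,2-dihydroxyethyl on a saturated chain carbon bound to a saturated ring carbon. Put another way, 2,3-dihydroxypropyl gives way to 2-acetamidoethyl. Within the data shown here, the measured step instead placed 3,4-dichlorophenyl where 3,4-difluorophenyl stood, so it says nothing direct about this side chain, and no measured step touches that change. No step beyond the scatter is expected in this assay, in either direction, although this expectation is poorly constrained. The estimate therefore starts from compound 1 at 800 nM. The expected change is a 1.1-fold higher number from compound 1 to compound 3 (0.05 log units; within the scatter). For compound 3 the estimated value is 900 nM, with an expected range of 300 nM to 2700 nM.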

Compound 3, half-maximal inhibitory concentration: 920 nM
Estimate against measurement, compound 3: 1.0-fold (0.01 log units) below; low and high end bracket the measured number.
By their numbers in this assay, from the lowest: compounds 1, 3 and 2 (each within the scatter of the next).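

Replacing 1,2-dihydroxyethyl with acetamidomethyl on a saturated chain carbon bound to a saturated ring carbon gives a 1.2-fold higher number from compound 1 to compound 3 (0.06 log units; within the scatter) in this assay. Going by these compounds alone, the earlier step changed only the 3,4-difluorophenyl group, so this is the first reading on the side chain, and it shows that the two hydroxyl groups of compound 1 are not needed to keep the activity of compound 1 in this cell test: compound 3 lacks both, carries an amide instead, and cannot be told apart from compound 1. No measurement at hand explains why two such different side chains read alike.

On these data alone, whether a simple amine, a carboxylic acid or a longer chain at this place would also read alike remains open. So does whether acetamidomethyl would behave the same way in a compound carrying 3,4-dichlorophenyl.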